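The source may report more compounds than this note shows. Statements on the series, on what has been measured and on what is new or still open speak of the compounds shown alone.

Compound 1, `CCCc1cn([C@H]2C[C@@H]3OP(=O)(O)OC[C@H]3O2)c(=O)[nH]c1=O`, is the starting point of this account. In a functional assay on Raji cells (Homo sapiens) (on this read-out higher numbers stand for weaker inhibition and lower numbers for stronger inhibition), compound 1 gives > 500 ug/mL, and this is a limit of the assay rather than a number. Compound 2, `CC(C)c1cn([C@H]2C[C@@H]3OP(=O)(O)OC[C@H]3O2)c(=O)[nH]c1=O`, carries isopropyl in place of propyl on an aromatic carbon. In this assay compound 2 gives > 500 ug/mL, again a limit. Compound 3, `CCCc1cn([C@H]2C[C@H](O)[C@@H](CO)O2)c(=O)[nH]c1=O`, shares the propyl-bearing part of compound 1 but differs in the rest of the structure. In this assay compound 3 gives > 500 ug/mL, also a limit. Among the compounds with values here, the one measured single-point step, a step that the two limits leave unreadable from compound 1 to compound 2, cannot be read because of the limit of > 500 ug/mL in this assay, at which 3 of the 3 values shown sit. Compound 1 thus stands at a limit, and the two other values shown sit at that same limit.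

Compound 4 is `CCCCCCCCc1cn([C@H]2C[C@@H]3OP(=O)(O)OC[C@H]3O2)c(=O)[nH]c1=O`. Relative to compound 1 the change is pentyl in place of hydrogen on a saturated chain carbon, three bonds along the chain from an aromatic carbon. Within the data shown here, no measured step bears on a change of this kind, and the only step at hand, a step that the two limits leave unreadable from compound 1 to compound 2, has no readable size, so there is nothing from which to expect a direction or a size beyond the scatter. With three values all at the limit, the expectation for compound 4 is that it too sits there. Compound 4 is expected to give about 500 ug/mL, within 150 ug/mL to 2000 ug/mL. The step this estimate implies, a number no higher from compound 1 to compound 4 (the limit leaves the size open), is expected to be no larger than the scatter.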

Compound 4, concentration for 50% inhibition: 165 ug/mL
Beside the measured number, compound 4's estimate is 3.0-fold (0.48 log units) above it, within the range that was stated.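

Among the compounds shown, lengthening the chain on this aromatic carbon to octyl is the only change that brings a reading inside the range of this assay, giving an at least 3.0-fold lower number from compound 1 to compound 4 (0.48 log units; beyond the scatter) and an at least 3.0-fold lower number from compound 2 to compound 4 (0.48 log units; beyond the scatter). The group at this position can therefore move the read-out on the core of compound 1, which the swap between propyl and isopropyl could not show, as both of those compounds stay at the limit. Each step has a limit at one end, so it gives only a minimum and its true size stays open: the limit of > 500 ug/mL in this assay, at which 3 of the 4 values shown sit.

The compounds shown leave open where between propyl and octyl the change sets in, and whether a longer chain such as decyl, or an octyl chain ending in an amine, would take the number lower still. They also leave open what octyl would do on the core of compound 3, since the only compound shown on that core carries propyl.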